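Sec-butyl to tert-butyl on the ester oxygen

The source may hold more compounds than are shown below. What is called first, only, known or untested is meant among the compounds shown, and "the series" means these compounds.

In an ADME assay on RAW264.7 cells (Mus musculus) for cytotoxicity, read by MTT assay, with a stated time of 24 h (on this read-out lower numbers stand for higher toxicity in this test and higher numbers for lower toxicity in this test), three esters on the shared core have been measured. Compound 1 (`CC/C=C\C[C@H]1C(=O)C=C[C@H]1CC(=O)OCC`) gives 146 uM, compound 2 (`CC/C=C\C[C@H]1C(=O)C=C[C@H]1CC(=O)OCCOCCO`) gives 166 uM, and compound 3 (`CC/C=C\C[C@H]1C(=O)C=C[C@H]1CC(=O)OC(C)CC`) gives 53 uM. Compound 3 has the lowest number of the three, beyond the scatter from both of the others.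

The next compound is compound 4 (`CC/C=C\C[C@H]1C(=O)C=C[C@H]1CC(=O)OC(C)(C)C`), which carries tert-butyl in place of sec-butyl on an oxygen next to a carbonyl group. The two have the same atoms, joined differently.

For the measured compounds named here, no measured step exchanges one of these groups for the other, so the evidence is indirect. Two modest steps, a 2.8-fold lower number from compound 1 to compound 3 (0.44 log units; beyond the scatter) and a 3.1-fold lower number from compound 2 to compound 3 (0.50 log units; beyond the scatter), show that changes at this oxygen can move the number beyond the scatter. Another, a 1.1-fold higher number from compound 1 to compound 2 (0.06 log units; within the scatter), stays within it. Neither direction is therefore established for the new change, and compound 3, at 53 uM, remains the closest reference.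

In this assay, the expected step is a 1.0-fold higher number from compound 3 to compound 4 (0.02 log units; within the scatter), with nothing beyond the scatter anticipated. Compound 4 is estimated at 55 uM, with an expected range of 25 uM to 120 uM.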

Compound 4, half-maximal toxic concentration: 33 uM
For compound 4 the middle estimate is 1.7-fold (0.22 log units) above the measured one, within the range that was stated.
By their numbers in this assay, from the lowest: compounds 4 and 3 (each within the scatter of the next); then compounds 1 and 2 (each within the scatter of the next).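

In this assay, moving the same atoms from sec-butyl to tert-butyl on an oxygen next to a carbonyl group gives a 1.6-fold lower number from compound 3 to compound 4 (0.21 log units; within the scatter) and does not separate the two esters. Set against the other two esters, tert-butyl gives both a 5.0-fold lower number from compound 2 to compound 4 (0.70 log units; beyond the scatter) and a 4.4-fold lower number from compound 1 to compound 4 (0.65 log units; beyond the scatter), so it falls on the same side as sec-butyl, and the four compounds divide into two pairs, with no compound shown going against that division: sec-butyl and tert-butyl in one, ethyl and 2-(2-hydroxyethoxy)ethyl in the other. No measurement shown here bears on why the numbers divide this way.

For the compounds shown here, with only two groups in each pair, it remains open what sec-butyl and tert-butyl share that sets them apart from ethyl and 2-(2-hydroxyethoxy)ethyl. Going by these compounds, it is also open whether a longer chain such as hexyl, a benzyl group or an ester chain ending in an amine would fall with compound 3 and compound 4 or with compound 1 and compound 2, and where the free carboxylic acid on the shared core would stand.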